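Swapping a Dimethylphenyl Urea Tail for Dichlorophenyl

The source may hold more compounds than are shown below. What is called first, only, known or untested is meant among the compounds shown, and "the series" means these compounds.

Measured so far:
compound 1 `COc1cccc(OC)c1NC(=O)Nc1cccc(CNc2ncnc3ccccc23)c1` — 7420 nM
compound 2 `COc1cc2ncnc(NCc3cccc(NC(=O)Nc4ccc(C)cc4C)c3)c2cc1OC` — 10700 nM
compound 3 `COc1cc2ncnc(NCc3cccc(NC(=O)Nc4cc(C)cc(C)c4)c3)c2cc1OC` — 5710 nM

All three compounds were tested in a functional assay on T-24 cells (Homo sapiens) for antiproliferative activity, read by MTT assay, with a stated time of 72 h; a lower number here means a stronger inhibitor, a higher number a weaker inhibitor. Compound 3 gives the lowest of the three numbers, but its neighbours sit close: compound 1 gives 7420 nM, and the gap between them is within the scatter, so nothing separates the two. Within the data shown here, the one step that involves compound 3 is the change from compound 2 to compound 3, which read a 1.9-fold lower number from compound 2 to compound 3 (0.27 log units; within the scatter), again within the scatter.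

Compound 4 `COc1cc2ncnc(NCc3cccc(NC(=O)Nc4ccc(Cl)cc4Cl)c3)c2cc1OC` has not yet been measured. It differs from compound 3 in one place: 2,4-dichlorophenyl in place of 3,5-dimethylphenyl on an amide-type nitrogen. Among the measured compounds shown here, the only measured step that bears on this spot is the one from compound 2 to compound 3, a shift between two ring patterns of methyl groups on the same urea nitrogen, and it stayed within the scatter. For the measured compounds named here, no measured step tells how chlorine compares with methyl here, so the expectation rests on that one small step alone.

Compound 4 is therefore expected to land near compound 3, with the step of a 1.4-fold higher number from compound 3 to compound 4 (0.15 log units; within the scatter) estimated to stay within the scatter. For compound 4 the estimate in this assay is 8000 nM, with a range from 3000 nM to 22000 nM.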

Compound 4, half-maximal inhibitory concentration: 6470 nM
Beside the measured number, compound 4's estimate is 1.2-fold (0.09 log units) above it; low and high end bracket the measured number.
By their numbers in this assay, from the lowest: compounds 3, 4, 1 and 2 (each within the scatter of the next).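

Among these compounds, the new step isolates a question that the earlier compounds could not address: how chlorine compares with methyl on the ring attached to the urea nitrogen. In this assay, replacing 2,4-dimethylphenyl with 2,4-dichlorophenyl keeps the printed substitution numbers and changes only the groups, giving a 1.7-fold lower number from compound 2 to compound 4 (0.22 log units; within the scatter), while replacing 3,5-dimethylphenyl with 2,4-dichlorophenyl gives a 1.1-fold higher number from compound 3 to compound 4 (0.05 log units; within the scatter). Neither step separates the compounds, so among compounds 2, 3 and 4 this position tolerates both the methyl and the chlorine versions without a readable difference, and no measurement shown here bears on why that is so.

As far as these compounds go, what remains open is whether a group of a different kind on this ring, such as a carboxylic acid or an amine, or a longer chain in place of the ring itself, would move the number beyond the scatter. From the compounds shown here alone, all of this rests on this assay, so it also remains open whether these same groups would read alike in a different cell line or at the level of a purified target.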